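Butylsulfanyl for Ethoxy: Cytotoxicity Expected to Stay Low

This account rests on a few compounds, and the source may have more. Where it says the series, first, only, none or still open, it means among the compounds named here.

In an ADME assay on HFF cells (Homo sapiens) for cytotoxicity, with a stated time of 8 days (on this read-out higher numbers stand for lower toxicity in this test and lower numbers for higher toxicity in this test), compound 1 `CCOc1nc(N)nc2c1ncn2/C=C1/CC1(CO)CO` gives > 300000 nM, which is a limit of the test rather than a number.
In this assay compound 2 `Nc1nc(NC2CCCCC2)c2ncn(/C=C3/CC3(CO)CO)c2n1` gives > 300000 nM, again a limit.
In this assay compound 3 `Nc1nc(SC2CCCC2)c2ncn(/C=C3/CC3(CO)CO)c2n1` gives > 300000 nM, again a limit.

Compound 1 therefore stands only at a limit, and all three values sit at the same place, (the limit of > 300000 nM in this assay, at which 3 of the 3 values shown sit). Within the data shown here, the steps a step that the two limits leave unreadable from compound 1 to compound 2 and a step that the two limits leave unreadable from compound 1 to compound 3 cannot be read in size, so they say only that neither change moved the value off the limit. Compound 4 `CCCCSc1nc(N)nc2c1ncn2/C=C1/CC1(CO)CO` differs from compound 1 by butylsulfanyl in place of ethoxy on an aromatic carbon. With every measured step unreadable, no size or direction in this assay can be drawn from them. Compound 4 is expected to sit at the limit again, with an estimate of 300000 nM in a range from 100000 nM to 1000000 nM. This estimate means an expected step of a number no higher from compound 1 to compound 4 (the limit leaves the size open).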

Compound 4, half-maximal cytotoxic concentration: > 300000 nM
Compound 4 gave a limit, no number (the forecaster's own chance of this, stated with the estimate: 85%); the middle value lies on the limit itself.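

Every step to compound 4 from compound 1, compound 2 or compound 3 joins two limits of the test, so none can be read in size: the limit of > 300000 nM in this assay, at which 4 of the 4 values shown sit.

From the compounds shown here alone, whether any of these four compounds would harm the cells at a higher concentration stays open in this assay.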